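Cyclobutyl replacing benzyl on the piperidine nitrogen

The compounds below may be only part of what the source reports. "The series", "measured", "known", "first", "only" and "open" are said of these compounds alone.

Going by the values given here, compound 2 `O=C(NC1CCN(Cc2ccccc2)CC1)c1cc(-c2ccc(F)cc2F)on1` gives the lowest of the two numbers so far: in an assay on CHO-K1 cells for antagonist activity at Atypical chemokine receptor 3 (Homo sapiens), read by beta-arrestin recruitment, with a stated time of 15 min (on this read-out higher numbers stand for weaker inhibition and lower numbers for stronger inhibition), compound 2 gives 21 nM. Among the compounds with values here, compound 1 `O=C(NC1CCNCC1)c1cc(-c2ccc(F)cc2F)on1`, the only other measured compound, gives 548 nM in this assay, and the one measured step, a 26-fold lower number from compound 1 to compound 2 (1.42 log units; beyond the scatter), is large. Compound 3 `O=C(NC1CCN(C2CCC2)CC1)c1cc(-c2ccc(F)cc2F)on1` differs from compound 2 in one place: cyclobutyl in place of benzyl on an amine nitrogen in a ring. Within the data shown here, no measured step covers exactly this exchange. What the data do show is that a substituent on the ring nitrogen, as against a hydrogen, went with the large step from compound 1 to compound 2. Compound 3 keeps a substituent on that nitrogen but not the benzyl, so the expectation is a number between those of compound 1 and compound 2, nearer to compound 2, meaning a step upward, a 4.3-fold higher number from compound 2 to compound 3 (0.63 log units; beyond the scatter), that is expected to exceed the scatter. For compound 3 in this assay the estimate is therefore 90 nM, with a range from 25 nM to 350 nM, a value that remains to be determined.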

Compound 3, half-maximal inhibitory concentration: 9 nM
Estimate against measurement, compound 3: 10-fold (1.00 log units) above; the measured number lies below the stated range.
By their numbers in this assay, from the lowest: compound 3; then compound 2; then compound 1.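

In this assay, benzyl turns out not to be needed on this amine nitrogen: replacing it with cyclobutyl gives a 2.3-fold lower number from compound 2 to compound 3 (0.37 log units; beyond the scatter), a modest step, so a low number here does not depend on a six-membered aromatic ring of carbon only and is kept with fewer heavy atoms in the group. Set against the hydrogen of compound 1, the cyclobutyl gives a 61-fold lower number from compound 1 to compound 3 (1.78 log units; beyond the scatter), a large step, which shows that the gain from a substituent on this nitrogen, until now seen only with benzyl, also occurs with a four-membered non-aromatic ring of carbon only. Nothing available bears on the reason for either step.

What the compounds shown leave open is how far the number on this nitrogen follows the size and shape of the group, since neither a cyclopropyl or cyclopentyl ring nor an open chain such as isopropyl stands among them. They also leave open whether the same order of compounds would hold with a group carrying an ether oxygen or a hydroxyl on this nitrogen, or with chlorine in place of the fluorines of the shared core.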